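Chlorine on the Phenyl Ring and Hepatocyte Clearance

The compounds below may be only part of what the source reports. "The series", "measured", "known", "first", "only" and "open" are said of these compounds alone.

Measured compounds:
compound 1 `COc1nc(C2=NOCC(c3ccccc3)N2)ccc1-n1cnc(C)c1`: 21 mL/min/kg
compound 2 `COc1nc(C2=NOCC(c3ccc(C(F)(F)F)cc3)N2)ccc1-n1cnc(C)c1`: 12 mL/min/kg
compound 3 `COc1nc(C2=NOCC(c3ccc(C(C)(C)C)cc3)N2)ccc1-n1cnc(C)c1`: 320 mL/min/kg

The three compounds share one core and differ only in what sits on the phenyl ring. In an ADME assay on cells (Hepatocyte, Homo sapiens) for pharmacokinetics (a higher number here means faster removal of the compound, a lower number slower removal), compound 1 gives 21 mL/min/kg, the second highest of the three numbers. Its nearest neighbour is compound 2: a 1.8-fold lower number from compound 1 to compound 2 (0.24 log units; within the scatter). Its furthest is compound 3: a 15-fold higher number from compound 1 to compound 3 (1.18 log units; beyond the scatter), so one replacement of a ring hydrogen left the number unchanged in practice, while another moved it a long way.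

Compound 4 `COc1nc(C2=NOCC(c3cccc(Cl)c3)N2)ccc1-n1cnc(C)c1` is not yet measured. It differs from compound 1 by chloro in place of hydrogen on an aromatic carbon. Among the compounds with values here, the two measured steps from compound 1 are the only guide, and they point in different directions. Since a single group in compound 2 gave a 1.8-fold lower number from compound 1 to compound 2 (0.24 log units; within the scatter), while the bulkier tert-butyl in compound 3 gave a 15-fold higher number from compound 1 to compound 3 (1.18 log units; beyond the scatter), a step no larger than the scatter is expected for compound 4, that is a 1.2-fold higher number from compound 1 to compound 4 (0.08 log units; within the scatter). Compound 4 is therefore estimated at 25 mL/min/kg, in a range from 10 mL/min/kg to 70 mL/min/kg.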

Compound 4, clearance: 15 mL/min/kg
Estimate against measurement, compound 4: 1.7-fold (0.22 log units) above; low and high end bracket the measured number.
By their numbers in this assay, from the lowest: compounds 2, 4 and 1 (each within the scatter of the next); then compound 3.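

In this assay chloro, placed meta to a large group, stays close to the unsubstituted phenyl of compound 1 (a 1.4-fold lower number from compound 1 to compound 4 (0.15 log units; within the scatter)) and close to the trifluoromethyl of compound 2 (a 1.3-fold higher number from compound 2 to compound 4 (0.10 log units; within the scatter)). Compounds 1, 2 and 4 therefore form one group within the scatter, and compound 3 is the only one outside it (a 21-fold lower number from compound 3 to compound 4 (1.33 log units; beyond the scatter)), although that last step changes both the group and its place on the ring. Nothing available explains why chloro and trifluoromethyl stay close to hydrogen while tert-butyl does not. The compounds shown leave open whether the large step belongs to tert-butyl itself or to its place on the ring, as 3-chlorophenyl is the only pattern of its kind here. As far as these compounds go, how an amine or a carboxylic acid on the phenyl ring would behave also remains open.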